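Working notes: aryl exchange from compound 2 to compound 3

The source may hold more compounds than are shown below. What is called first, only, known or untested is meant among the compounds shown, and "the series" means these compounds.

Measured compounds:
Compound 1 `Cc1cccc(-c2nc(CNc3ccc(C(=O)NO)cc3)n(-c3ccccc3)n2)c1`: in an assay on Sf9 cells for inhibition of protein deacetylase HDAC6 (Homo sapiens), read by fluorescence, with a stated time of 40 min (a lower number here means a stronger inhibitor, a higher number a weaker inhibitor), compound 1 gives 281 nM.
Compound 2 `Cc1ccsc1-c1nc(CNc2ccc(C(=O)NO)cc2)n(-c2ccccc2)n1`: in this assay compound 2 gives 30.7 nM.

Among the compounds with values here, compound 2 holds the lowest of the two numbers; its nearest neighbour is compound 1, and the single measured step runs a 9.2-fold lower number from compound 1 to compound 2 (0.96 log units; beyond the scatter). Compound 3 `O=C(NO)c1ccc(NCc2nc(-c3ccccc3Cl)nn2-c2ccccc2)cc1` is not yet measured. It differs from compound 2 in one place: 2-chlorophenyl in place of 3-methylthiophen-2-yl on an aromatic carbon.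

Only one step bears on this change, and only indirectly: the move from compound 1 to compound 2 replaced a six-membered carbon-only ring with the five-membered ring with 1 hetero atom, and that gave the modest drop shown. Compound 3 goes back to a six-membered carbon-only ring, though with a different substituent, so the expectation is a step back upward, of roughly the size seen between compounds 1 and 2 but tempered, as the substituent is not the same and no measured value speaks to that substituent. The estimated step is a 4.9-fold higher number from compound 2 to compound 3 (0.69 log units; beyond the scatter), worded as an expectation only.

Compound 3 is therefore expected at about 150 nM, within a range of 40 nM to 550 nM.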

Compound 3, half-maximal inhibitory concentration: 185 nM
Compound 3: the middle estimate sits 1.2-fold (0.09 log units) below what was measured, within the range that was stated.
By their numbers in this assay, from the lowest: compound 2; then compounds 3 and 1 (each within the scatter of the next).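

In this assay, 2-chlorophenyl in place of 3-methylthiophen-2-yl on this carbon of the five-membered aromatic ring with 3 nitrogen gives a 6.0-fold higher number from compound 2 to compound 3 (0.78 log units; beyond the scatter), so a second six-membered carbon-only ring also fails to match compound 2. The two six-membered rings, which carry different substituents at different ring positions, are separated by a 1.5-fold lower number from compound 1 to compound 3 (0.18 log units; within the scatter); compound 1 and compound 3 therefore cannot be told apart here, and among the three compounds only the 3-methylthiophen-2-yl group of compound 2 stands apart, on the lower side. Nothing measured on these compounds accounts for that gap in terms of any property of the groups.

The compounds shown do not separate the ring from its substituent, since the only five-membered ring among them carries a methyl group and both six-membered rings differ from it in ring and substituent at once. Plain thiophen-2-yl, 3-chlorothiophen-2-yl and 2-methylphenyl would pull these apart, while a pyridine ring or an aminophenyl group at this carbon remains open ground.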